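The source may hold more compounds than are shown below. What is called first, only, known or untested is meant among the compounds shown, and "the series" means these compounds.

Working notes on the series. Going by the values given here, in a functional assay on HepG2 cells (Homo sapiens) for inhibition, read by scintillation counting, with a stated time of 2 h (a lower number here means a stronger inhibitor, a higher number a weaker inhibitor), compound 1 (`CC(=O)N1CCC(C(=O)N2CCC(N3CCN(C(=O)c4cc(-c5ccc(C)cc5)nc(-c5ccc6[nH]c(C)c(C)c6c5)c4)CC3)CC2)CC1`) gives 294 nM as the only number so far, and its core differs from that of the other compounds. Compound 2 (`CCNC(=O)Nc1sc2ccccc2c1C(=O)N1CCN(C2CCN(C(C)=O)CC2)CC1`) stands at "not determined" (no result reported) in this assay and offers no number. Compound 3 (`CCCCC(=O)N1CCC(N2CCN(C(=O)c3c(NC(=O)NCC)sc4ccccc34)CC2)CC1`) likewise stands at "not determined" (no result reported) in this assay and so has no position on the scale from which to count.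

Compound 4 (`CCNC(=O)Nc1sc2ccccc2c1C(=O)N1CCN(C2CCN(C(=O)OCC)CC2)CC1`) keeps the rest of compound 3 and changes one group (ethoxy in place of butyl on a carbonyl carbon) with ethoxy in place of butyl on a carbonyl carbon. Among the compounds with values here, no measured step exists, and the step from compound 3 cannot be anchored to a number. The working expectation is no shift beyond the usual scatter, in either direction, but this rests on the structural change alone. Within the data shown here, the only loose reference is compound 1 at 294 nM on another core, so the range has to stay wide. For compound 4 the expected value is 1500 nM with an estimated span from 150 nM to 10000 nM as the range.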

Compound 4, half-maximal inhibitory concentration: 228 nM
For compound 4 the middle estimate is 6.6-fold (0.82 log units) above the measured one; the range from low to high includes it.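

In this assay, going by these compounds alone, compound 4 gives 228 nM but no step from compound 3 can be read, as compound 3 holds no single number. The compounds shown leave open what butylcarbonyl to ethoxycarbonyl does to inhibition on the shared core. No evidence bears on this result.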